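Fluorine on the sulfonyl ring of a nitro cinnamoyl sulfonamide

The compounds below may be only part of what the source reports. "The series", "measured", "known", "first", "only" and "open" are said of these compounds alone.

Measured compounds:
compound 1 `O=C(/C=C/c1ccccc1)NS(=O)(=O)c1ccc(F)cc1`, 2.1 ug/mL
compound 2 `O=C(/C=C/c1ccc(Cl)cc1)NS(=O)(=O)c1ccc(F)cc1`, 2 ug/mL
compound 3 `O=C(/C=C/c1ccc([N+](=O)[O-])cc1)NS(=O)(=O)c1ccccc1`, 4.8 ug/mL

In a functional assay on B16-F10 cells (Mus musculus) for antiproliferative activity, read by ELISA and MTT assay, with a stated time of 48 h (on this read-out higher numbers stand for weaker inhibition and lower numbers for stronger inhibition), compound 3 gives the highest number of the three, standing beyond the scatter above compound 1 and above compound 2. Compound 4 `O=C(/C=C/c1ccc([N+](=O)[O-])cc1)NS(=O)(=O)c1ccc(F)cc1` differs from compound 3 by fluoro in place of hydrogen on an aromatic carbon, at a carbon para to a large group. Among the measured compounds shown here, the only measured step, a 1.1-fold lower number from compound 1 to compound 2 (0.02 log units; within the scatter), concerns a different ring and a different halogen, so nothing directly bears on adding fluorine to the sulfonyl ring. For the measured compounds named here, compound 1 and compound 2 both carry that fluorine and give numbers close together, but compound 3 differs from them in two places, so no step for fluorine alone can be read. Compound 4 is therefore expected to move by a 1.3-fold lower number from compound 3 to compound 4 (0.10 log units; within the scatter), a step within the scatter. The estimate for compound 4 is 3.8 ug/mL, between 1.6 ug/mL and 9 ug/mL.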

Compound 4, half-maximal inhibitory concentration: 2.2 ug/mL
Estimate against measurement, compound 4: 1.7-fold (0.24 log units) above; measured number inside the range.
By their numbers in this assay, from the lowest: compounds 2, 1 and 4 (each within the scatter of the next); then compound 3.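

In this assay, among the compounds shown here, fluoro in place of hydrogen on the sulfonyl-bearing ring, at the carbon para to a large group, gives a 2.2-fold lower number from compound 3 to compound 4 (0.34 log units; beyond the scatter) and is the first single-change step beyond the scatter. With that fluoro present, nitro in place of chloro gives a 1.1-fold higher number from compound 2 to compound 4 (0.04 log units; within the scatter) and nitro in place of hydrogen gives a 1.0-fold higher number from compound 1 to compound 4 (0.02 log units; within the scatter), so these three substituents on the other ring remain indistinguishable. Nothing measured here accounts for the fluoro step.

As far as these compounds go, whether fluoro gives the same step alongside hydrogen or chloro instead of nitro remains open. So does how an amine or a methoxy group would compare with fluoro at that carbon.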